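From Nitro to Methyl: Compound 4 Before Measurement

A few compounds are considered here, and "the series" means these few. Any claim that something is new, unique, unknown or untested is made for them only; others in the source may bear on it.

Measured compounds:
compound 1, `COc1ccc(Nc2nc3c(Cl)ncnc3s2)cc1`: 11500 nM
compound 2, `O=[N+]([O-])c1ccc(Nc2nc3c(N4CCCC4)ncnc3s2)cc1`: > 30000 nM
compound 3, `Clc1ncnc2sc(Nc3cccc(Br)c3)nc12`: 12600 nM

For the measured compounds named here, in an assay on CHO cells for displacement of a labelled ligand from adenosine receptor A1 (Homo sapiens), read by scintillation counting, with a stated time of 3 h (a higher number here means a weaker inhibitor, a lower number a stronger inhibitor), compound 1 gives 11500 nM and compound 3 gives 12600 nM, the two numbers that the series so far provides. Compound 2 gives only > 30000 nM, which is a limit of the assay and not a number. Going by the values given here, compound 2 thus stands at the limit of > 30000 nM in this assay, at which 1 of the 3 values shown sits, so no step between it and either measured compound can be sized, and no step between any two measured compounds is known at all.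

Compound 4 is `Cc1ccc(Nc2nc3c(N4CCCC4)ncnc3s2)cc1`. It differs from compound 2 by methyl in place of nitro on an aromatic carbon. Since compound 2 shows only a limit, the step in this assay cannot be anchored on a measured pair; the direction is open, and a change no larger than the scatter is as plausible as a gain.

Compound 4 is expected to give about 20000 nM, within 5000 nM to 60000 nM. The expected step is an at least 1.5-fold lower number from compound 2 to compound 4 (0.17 log units; that floor lies within the scatter), to be judged only once compound 4 is read.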

Compound 4, inhibition constant: > 100000 nM
Compound 4 was reported as a limit; the forecaster's own chance of this, stated with the estimate: 40%; at least 5.0-fold (0.69 log units) between middle value and limit.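

In this assay, for the compounds shown here, compound 4 gives > 100000 nM, which is a limit and not a number; compound 2 also shows only a limit, so no step between compound 2 and compound 4 can be read. The compounds shown leave open whether methyl in place of nitro on an aromatic carbon changes the inhibition constant at all.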